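The source may hold more compounds than are shown below. What is called first, only, known or untested is meant among the compounds shown, and "the series" means these compounds.

Measured so far in a functional assay on HEL cells (Homo sapiens) for cytotoxicity; a lower number here means that less compound is tolerated, a higher number that more compound is tolerated:
- compound 1 `CO[C@@H]1[C@@H](OC)[C@H](c2ccccc2)O[C@@H]2CO[C@@H](c3ccc([N+](=O)[O-])cc3)O[C@@H]12`: "not determined" (no result reported)
- compound 2 `CO[C@@H]1[C@@H](OC)[C@H](c2ccccc2)O[C@@H]2CO[C@@H](c3ccc(Cl)cc3)O[C@@H]12`: > 50 ug/mL
- compound 3 `CO[C@@H]1[C@@H](OC)[C@H](c2ccccc2)O[C@@H]2CO[C@@H](c3ccccc3Cl)O[C@@H]12`: "not determined" (no result reported)

The three compounds share one core, yet the series offers little to work from. Among the compounds with values here, neither compound 1 nor compound 3 has a reported result in this assay, so no step between measured compounds can be read. Within the data shown here, compound 2 is the only one with a reading, and that reading is a limit of the assay and not a number: > 50 ug/mL. It therefore stands at that limit, the sole entry of its kind among the three: the limit of > 50 ug/mL in this assay, at which 1 of the 3 values shown sits.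

The next compound to be tested, compound 4 `CO[C@@H]1[C@@H](OC)[C@H](c2ccccc2)O[C@@H]2CO[C@@H](c3ccc(-c4ccccc4)cc3)O[C@@H]12`, keeps the core of compound 2 and has phenyl in place of chloro on an aromatic carbon, para to a large group: phenyl in place of chloro on an aromatic carbon. Among the measured compounds shown here, with no measured step to guide the expectation, the change is expected to leave the half-maximal cytotoxic concentration without a shift beyond the usual scatter, in either direction. The estimated step is a number no higher from compound 2 to compound 4 (the limit leaves the size open). The assay may well report only a limit again. For compound 4 the expected value is 50 ug/mL, with an estimated range from 20 ug/mL to 100 ug/mL.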

Compound 4, half-maximal cytotoxic concentration: > 50 ug/mL
Compound 4 ended at the assay's limit (the forecaster's own chance of this, stated with the estimate: 70%); the middle value lies on the limit itself.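

Compound 2 and compound 4 both rest on a limit and not on a number in this assay, so no step can be read between them: the limit of > 50 ug/mL in this assay, at which 2 of the 4 values shown sit.

The compounds shown leave open how far phenyl in place of chloro moves the half-maximal cytotoxic concentration, and at what concentration either compound becomes cytotoxic in this assay.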